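Aryl exchange on the shared core: working notes

The source may hold more compounds than are shown below. What is called first, only, known or untested is meant among the compounds shown, and "the series" means these compounds.

In a physicochemical assay for lipophilicity (on this read-out higher numbers stand for higher lipophilicity and lower numbers for lower lipophilicity), compound 1 `COc1ccc(C2C[C@@]3(ON2c2ccccc2)C(=O)O[C@@H]2[C@H]3CC[C@H](C)[C@]3(O)C=CC(=O)[C@@]23C)cc1` gives 3.25 and compound 2 `C[C@H]1CC[C@@H]2[C@@H](OC(=O)[C@]23CC(c2c(F)cccc2F)N(c2ccccc2)O3)[C@]2(C)C(=O)C=C[C@@]12O` gives 3.42. Among the compounds with values here, these two numbers lie within the scatter of each other, so compound 2 stands level with the only other measured compound.

The change to compound 3 `COc1ccc(C2C[C@@]3(ON2c2ccccc2)C(=O)O[C@@H]2[C@H]3CC[C@H](C)[C@]3(O)C=CC(=O)[C@@]23C)cc1Br` is 3-bromo-4-methoxyphenyl in place of 2,6-difluorophenyl on a saturated ring carbon, with 3-bromo-4-methoxyphenyl in place of 2,6-difluorophenyl on a saturated ring carbon, next to the ring nitrogen. The rest of the structure stays the same.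

Within the data shown here, one measured step bears on this place, namely a number 0.17 log units higher from compound 1 to compound 2 (within the scatter) with 2,6-difluorophenyl in place of 4-methoxyphenyl. Among the measured compounds shown here, no measured compound carries bromine, so that single step is only a weak guide to the size of this one. The direction is expected to be upward and the size modest, close to the edge of the scatter. The estimate is a number 0.33 log units higher from compound 2 to compound 3 (beyond the scatter) in this assay as a working expectation. Compound 3 is estimated at 3.75 with an expected range from 3.35 to 4.15 for a measured number.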

Compound 3, partition coefficient: 3.98
The estimate for compound 3 lay 0.23 log units below the measured number; low and high end bracket the measured number.
By their numbers in this assay, from the lowest: compounds 1 and 2 (each within the scatter of the next); then compound 3.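

Aryl exchange at this position can move the number in this assay beyond the scatter, which the step between the first two compounds did not show: the result is a number 0.56 log units higher from compound 2 to compound 3 (beyond the scatter) for 3-bromo-4-methoxyphenyl in place of 2,6-difluorophenyl on the saturated ring carbon. That exchange replaces a whole aryl group. The more specific reading comes from bromo in place of hydrogen on an aromatic carbon, which gives a number 0.73 log units higher from compound 1 to compound 3 (beyond the scatter) with the rest of the structure unchanged. Compound 3 therefore stands above both compound 1 and compound 2 in this assay by steps beyond the scatter, so a single added bromo is enough to separate compounds that otherwise share the core and the 4-methoxyphenyl group.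

Still open, from the compounds shown here alone, is whether another substituent in place of that bromo, such as chloro, an amine or a carboxylic acid, would shift the number in this assay in the same direction, or in the opposite one. Nothing among the available data accounts for the size of either new step.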